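The source may report more compounds than this note shows. Statements on the series, on what has been measured and on what is new or still open speak of the compounds shown alone.

Working notes on the series in an assay on HEK293 cells for displacement of a labelled ligand from NPC1-like intracellular cholesterol transporter 1 (Homo sapiens); a higher number here means a weaker inhibitor, a lower number a stronger inhibitor.

Three compounds share one core, and the three numbers sit close together. Compound 1 `CC(C)(C)c1ccc(C(=O)N2CCC3(CC2)C(=O)N(CC(=O)N2CCC(O)CC2)CN3c2ccccc2)cc1` gives 4700 nM. Compound 2 `CCc1nn(CC)c(C2CCN(C(=O)CN3CN(c4ccccc4)C4(CCN(C(=O)c5ccc(C(C)(C)C)cc5)CC4)C3=O)CC2)c1CC` gives 4600 nM. Compound 3 `NC(=O)C1CCCN(C(=O)CN2CN(c3ccccc3)C3(CCN(C(=O)c4ccc(C5CCCCC5)cc4)CC3)C2=O)C1` gives 3100 nM. Compound 2 stands second highest of the three numbers; its nearest neighbour is compound 1 and its furthest is compound 3, both within the scatter, so no order among the three can be read from these values.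

Among the measured compounds shown here, the one step measured at a single place is a 1.0-fold lower number from compound 1 to compound 2 (0.01 log units; within the scatter). It sits on the same saturated ring carbon that is changed in the next compound.

Compound 4 `CC(C)(C)OC(=O)NC1CCN(C(=O)CN2CN(c3ccccc3)C3(CCN(C(=O)c4ccc(C(C)(C)C)cc4)CC3)C2=O)CC1` is not yet measured. Its difference from compound 2 is (tert-butoxycarbonyl)amino in place of 1,3,4-triethyl-1H-pyrazol-5-yl on a saturated ring carbon. For the measured compounds named here, the only step that bears on it is the one from compound 1 to compound 2, which exchanged a small group for a large one at this carbon and moved nothing beyond the scatter; compound 3 carries yet another group at a ring carbon of the same kind and also lies within the scatter of the other two. On this basis no step beyond the scatter is expected in this assay in either direction.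

Compound 4 is therefore expected to give about 4600 nM, with a range from 2000 nM to 10000 nM. The expected step of no change at the digits printed from compound 2 to compound 4 (within the scatter) is thus estimated to be flat.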

Compound 4, half-maximal inhibitory concentration: 8300 nM
Estimate against measurement, compound 4: 1.8-fold (0.26 log units) below; the range from low to high includes it.
By their numbers in this assay, from the lowest: compounds 3, 2, 1 and 4 (each within the scatter of the next, the first and the last beyond it).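

With (tert-butoxycarbonyl)amino on the saturated ring carbon, this assay shows a 1.8-fold higher number from compound 2 to compound 4 (0.26 log units; within the scatter) and a 1.8-fold higher number from compound 1 to compound 4 (0.25 log units; within the scatter) at this position. Compound 4 thus adds a third group here, and none of the steps among hydroxy, 1,3,4-triethyl-1H-pyrazol-5-yl and (tert-butoxycarbonyl)amino leaves the scatter. Compared with the step from compound 1 to compound 2, this change also tests a group with no ring and with a hydrogen-bond donor against a five-membered aromatic ring with no hydrogen-bond donors, and the number still stays within the scatter, while no measurement here bears on the reason for these values.

The compounds shown leave open whether a free amine or a carboxylic acid on this saturated ring carbon would give a step beyond the scatter, since the three groups compared here all carry no net charge or, for hydroxy, are not described on that point. They also leave open whether the same flat picture at this carbon would hold with cyclohexyl in place of tert-butyl on the benzene ring of the core.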